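Swapping the urea's aryl group on a shared core

The source may hold more compounds than are shown below. What is called first, only, known or untested is meant among the compounds shown, and "the series" means these compounds.

Within the data shown here, compound 1, `COc1cc(NC(=O)Nc2cc(Nc3cccc(C(C)(C)C)c3)ncn2)cc(OC)c1`, is one of two compounds measured in a functional assay on NCI-H226 cells (Homo sapiens) for inhibition, read by MTT assay, with a stated time of 48 h, tested at 10 uM; on this read-out higher numbers stand for more inhibition at the one concentration tested (going by the name of the read-out) and lower numbers for less inhibition. In this assay compound 1 gives 40%, the higher of the two numbers. Its companion is compound 2, `COc1cc(NC(=O)Nc2cc(Nc3cc(C)cc(F)c3)ncn2)cc(OC)c1`, which gives 35.3% in this assay; the step of a number 4.7 percentage points lower from compound 1 to compound 2 (within the scatter) lies within the usual scatter, so the two are not told apart. That step changes the group on a nitrogen attached to an aromatic ring, leaving the other end untouched.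

The untested compound 3, `CC(C)(C)c1cccc(Nc2cc(NC(=O)Nc3c(Cl)cccc3Cl)ncn2)c1`, changes the other end: 2,6-dichlorophenyl in place of 3,5-dimethoxyphenyl on an amide-type nitrogen. Among the measured compounds shown here, the only measured step here sits at a different place, so there is nothing that bears directly on this change, and no direction can be argued from the numbers. The expected step is therefore a number 2 percentage points lower from compound 1 to compound 3 (within the scatter), essentially none beyond the scatter. In this assay compound 3 is expected to give about 38%, with a broad range from 10% to 70% reflecting the lack of a comparable measured step.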

Compound 3, a percentage reported as inhibition, at one concentration (the size of the read-out at that concentration, not a potency): 36.5%
For compound 3 the middle estimate is 1.5 percentage points above the measured one; low and high end bracket the measured number.
By their numbers in this assay, from the lowest: compounds 2, 3 and 1 (each within the scatter of the next).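

The far end of the urea now has a measured step of its own: in this assay, putting 2,6-dichlorophenyl in place of 3,5-dimethoxyphenyl on an amide-type nitrogen gives a number 3.5 percentage points lower from compound 1 to compound 3 (within the scatter). Even though the entering group carries chlorine where the leaving group carries oxygen, and has no hydrogen-bond acceptors, this change cannot be told apart from repeated measurement of a single compound, so these two aryl groups are not distinguished at this position. Nothing at hand accounts for this result.

The compounds shown leave open whether a group of a different kind on this amide-type nitrogen, such as a phenyl ring bearing a carboxylic acid or a morpholine, would shift the number beyond the scatter. They also leave open what happens when 2,6-dichlorophenyl is paired with 3-fluoro-5-methylphenyl on the shared core, and whether such a pairing would behave as the two separate changes do.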